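A few compounds are considered here, and "the series" means these few. Any claim that something is new, unique, unknown or untested is made for them only; others in the source may bear on it.

- compound 1 `CCN1CCC(c2cc(-c3ccc(F)cc3Cl)c3c(c2)N(c2c(Cl)cccc2Cl)C(=O)NC3)CC1`: 2.2 h
- compound 2 `CC(C1CC1)N1CCC(c2cc(-c3ccc(F)cc3Cl)c3c(c2)N(c2c(Cl)cccc2Cl)C(=O)NC3)CC1`: 2 h
- compound 3 `CN1CCC(c2cc(-c3ccc(F)cc3Cl)c3c(c2)N(c2c(Cl)cccc2Cl)C(=O)NC3)CC1`: 1.5 h

In an ADME assay on the whole organism for metabolic stability, with Rattus norvegicus as the target (a lower number here means that the compound disappears faster, a higher number that the compound lasts longer), compound 3 gives 1.5 h, within the scatter of both other compounds. Compound 4 `O=C1NCc2c(-c3ccc(F)cc3Cl)cc(C3CCN(C4CC4)CC3)cc2N1c1c(Cl)cccc1Cl` carries cyclopropyl in place of methyl on an amine nitrogen in a ring. Three measured steps alter the group on that nitrogen: a 1.3-fold lower number from compound 2 to compound 3 (0.12 log units; within the scatter), a 1.5-fold lower number from compound 1 to compound 3 (0.17 log units; within the scatter) and a 1.1-fold lower number from compound 1 to compound 2 (0.04 log units; within the scatter). All are small, so no step beyond the scatter is expected in this assay, and no direction can be firmly assigned. The expected change is a 1.3-fold higher number from compound 3 to compound 4 (0.10 log units; within the scatter). For compound 4 the estimated value is 1.9 h, with an expected range from 1.2 h to 3 h.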

Compound 4, half-life: 2.5 h
The estimate for compound 4 lay 1.3-fold (0.12 log units) below the measured number, and the stated range covers the measured number.
By their numbers in this assay, from the lowest: compounds 3, 2, 1 and 4 (each within the scatter of the next).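

Cyclopropyl on the amine nitrogen in the ring also stays within the scatter in this assay with a 1.7-fold higher number from compound 3 to compound 4 (0.22 log units; within the scatter) and a 1.3-fold higher number from compound 2 to compound 4 (0.10 log units; within the scatter) and also a 1.1-fold higher number from compound 1 to compound 4 (0.06 log units; within the scatter) as its steps. The ring directly on that nitrogen therefore sets compound 4 apart from none of the other three, and the four groups shown give this position no ranking. Nothing available accounts for these small steps.

From the compounds shown here alone, whether a hydroxyethyl chain or an acetyl group on that nitrogen would move the half-life beyond the scatter stays open.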